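The compounds below may be only part of what the source reports. "The series", "measured", "known", "first", "only" and "open" are said of these compounds alone.

Measured in a functional assay on Rec1 cells (Homo sapiens) for inhibition, read by luminescence and CellTiter-Glo, with a stated time of 72 h; a lower number here means a stronger inhibitor, a higher number a weaker inhibitor:
Compound 1 `C/C=C/C(=O)Nc1ccc(Cn2nc(-c3ccc(Oc4ccccc4)cc3)cc2C(=O)OCC)cc1` gives 13100 nM
Compound 2 `C/C=C/C(=O)Nc1ccc(Cn2nc(-c3ccc(Oc4ccccc4)cc3)cc2CO)cc1` gives 12200 nM

Compound 1 stands level with compound 2. Compound 3 `CCOC(=O)c1cc(-c2ccc(Oc3ccccc3)cc2)nn1Cc1ccc(NC(=O)CCl)cc1` differs from compound 1 at one place (chloromethyl in place of prop-1-en-1-yl on a carbonyl carbon), with chloromethyl in place of prop-1-en-1-yl on a carbonyl carbon. Going by the values given here, the only measured step (a 1.1-fold lower number from compound 1 to compound 2 (0.03 log units; within the scatter)) lies within the scatter and concerns a different place, an aromatic carbon, so it gives no direct guide to this change. A modest move to a lower number in this assay is expected, with wide uncertainty (a 2.2-fold lower number from compound 1 to compound 3 (0.34 log units; beyond the scatter)). The estimated value for compound 3 is 6000 nM (range 1500 nM to 16000 nM).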

Compound 3, half-maximal inhibitory concentration: 400 nM
Estimate against measurement, compound 3: 15-fold (1.18 log units) above; the whole stated range lies above it.
By their numbers in this assay, from the lowest: compound 3; then compounds 2 and 1 (each within the scatter of the next).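

In this assay, chloromethyl in place of prop-1-en-1-yl on the carbonyl carbon gives a 33-fold lower number from compound 1 to compound 3 (1.52 log units; beyond the scatter). Going by these compounds alone, this position therefore responds strongly to the group it carries, unlike the aromatic carbon, where the only earlier change gave a 1.1-fold lower number from compound 1 to compound 2 (0.03 log units; within the scatter), within the scatter. Nothing available accounts for the size of this step.

Still open, from the compounds shown here alone, is whether a plain methyl, ethenyl or bromomethyl on this carbonyl carbon would keep the lower number. Also open, going by these compounds, is whether chloromethyl gives a similar result with hydroxymethyl in place of ethoxycarbonyl.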